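Aryl replacement on the shared core: notes toward compound 4

The source may report more compounds than this note shows. Statements on the series, on what has been measured and on what is new or still open speak of the compounds shown alone.

Three compounds of the series have numbers in a functional assay, with a stated time of 150 min; a lower number here means a stronger inhibitor, a higher number a weaker inhibitor. Compound 1 `Cn1c(NN)nc(-c2cccc(O)c2O)c(C#N)c1=O` gives 44 ug/mL, compound 3 `Cn1c(NN)nc(-c2ccc(Cl)cc2)c(C#N)c1=O` gives 59 ug/mL, and compound 2 `CCOC(=O)c1cnn(-c2nc(-c3ccc(Cl)cc3)c(C#N)c(=O)n2C)c1N` gives 87 ug/mL. Compound 2 stands at the highest of the three numbers, but its distance to compound 3 and its distance to compound 1 both fall within the usual scatter, so the three values cannot be separated from one another and no order is read from them.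

Compound 4 `CCOC(=O)c1cnn(-c2nc(-c3cccs3)c(C#N)c(=O)n2C)c1N` remains to be measured. Relative to compound 2 it differs in one place: thiophen-2-yl in place of 4-chlorophenyl on an aromatic carbon. Going by the values given here, no pair of measured compounds carries this change, and the measured values give no hint of a direction for it. The expected step of a 1.1-fold lower number from compound 2 to compound 4 (0.04 log units; within the scatter) is therefore small and within the scatter, with no direction preferred. Compound 4 is expected to give about 80 ug/mL in this assay, with a range from 40 ug/mL to 160 ug/mL.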

Compound 4, half-maximal inhibitory concentration: 98 ug/mL
Estimate against measurement, compound 4: 1.2-fold (0.09 log units) below, within the range that was stated.
By their numbers in this assay, from the lowest: compounds 1, 3, 2 and 4 (each within the scatter of the next, the first and the last beyond it).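

In this assay, going by these compounds alone, thiophen-2-yl in place of 4-chlorophenyl gives a 1.1-fold higher number from compound 2 to compound 4 (0.05 log units; within the scatter), the first step that reads this aromatic carbon, ortho to a cyano group, on its own. With the rest of compound 2 held fixed, the five-membered sulfur ring and the chlorine-bearing six-membered carbon ring cannot be told apart here, so this single exchange shows no measurable effect of the aryl group at this position. No measured property of either group is available that bears on this result.

Still open, going by these compounds, is whether any group at this position moves the number beyond the scatter, for example an unsubstituted pyridyl ring, a carboxylic acid or a morpholine ring. Also open, on these data alone, is whether thiophen-2-yl behaves the same way on the core of compound 3.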